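A Thiazole Amide Replaces the Acetyl on the Core

The compounds below may be only part of what the source reports. "The series", "measured", "known", "first", "only" and "open" are said of these compounds alone.

Compound 1 `CCCCNc1nc(N)nc2c1CN(C(C)=O)CC2` carries an acetyl on the ring nitrogen of the shared core. In an assay on HEK293 cells for agonist activity at Toll-like receptor 8 (Homo sapiens), read by a luciferase reporter, with a stated time of 6 h (a lower number here means that less compound is needed, a higher number that more compound is needed for the effect), compound 1 gives 0.5 uM, the second highest of the three numbers measured. Compound 3 `CCCCNc1nc(N)nc2c1CN(Cc1ccc(C(C)(C)C)cc1)CC2` gives 0.66 uM, which lies within the scatter of compound 1, while compound 2 `CCCCNc1nc(N)nc2c1CN(Cc1ccc(C(F)(F)F)cc1)CC2` gives 0.23 uM, a lower number that lies beyond the scatter. Going by the values given here, the only step between measured compounds that differ in one place, a 2.9-fold higher number from compound 2 to compound 3 (0.46 log units; beyond the scatter), concerns a different part of the structure and does not touch the carbonyl carbon that changes here.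

Compound 4 `CCCCNc1nc(N)nc2c1CN(C(=O)c1csc(N)n1)CC2` differs from compound 1 in one place: 2-amino-1,3-thiazol-4-yl in place of methyl on a carbonyl carbon. Among the compounds with values here, no measured step bears directly on this change, and the three known numbers span only a narrow window, so no step beyond the scatter is expected in either direction. The value of compound 4 in this assay is expected to be 0.4 uM, between 0.1 uM and 1.5 uM. That estimate means an expected step of a 1.3-fold lower number from compound 1 to compound 4 (0.10 log units; within the scatter).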

Compound 4, minimum effective concentration: 6.9 uM
For compound 4 the middle estimate is 17-fold (1.24 log units) below the measured one; measured number outside the range, above it.
By their numbers in this assay, from the lowest: compound 2; then compounds 1 and 3 (each within the scatter of the next); then compound 4.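

In this assay, 2-amino-1,3-thiazol-4-yl in place of methyl on a carbonyl carbon gives a 14-fold higher number from compound 1 to compound 4 (1.14 log units; beyond the scatter), a large step well beyond the scatter. The earlier compounds shown here offered no step at this carbonyl carbon; this one shows that the group placed there can strongly change how much compound is needed, and that this exchange raises that amount. No measurement at hand accounts for the rise.

On these data alone, it remains open whether the rise goes with the thiazole ring or with its amino group, and a phenyl or an unsubstituted thiazol-4-yl on the same carbonyl carbon would separate the two. Also open, as far as these compounds go, is how a longer chain such as propyl in place of methyl would read in this assay.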